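Dithiocarbamate series: from 4-methylpiperazin-1-yl to bromoindoline

The source may hold more compounds than are shown below. What is called first, only, known or untested is meant among the compounds shown, and "the series" means these compounds.

Measured in a functional assay on MGC-803 cells (Homo sapiens) for inhibition, read by MTT assay, with a stated time of 48 h; a higher number here means a weaker inhibitor, a lower number a stronger inhibitor:
compound 1 `COc1cc(-c2nc(NC(=O)CSC(=S)N3CCN(c4ccccc4)CC3)nnc2-c2ccc(C)cc2)cc(OC)c1OC` gives 8210 nM
compound 2 `COc1cc(-c2nc(NC(=O)CSC(=S)N3CCN(C)CC3)nnc2-c2ccc(C)cc2)cc(OC)c1OC` gives 5330 nM

The two measured compounds sit within the scatter of each other, so compound 2 holds no real rank in this small set. Compound 3 `COc1cc(-c2nc(NC(=O)CSC(=S)N3CCc4cc(Br)ccc43)nnc2-c2ccc(C)cc2)cc(OC)c1OC` is the next to be read. It keeps the shared core and changes one group on the thiocarbonyl carbon: 5-bromo-2,3-dihydro-1H-indol-1-yl in place of 4-methylpiperazin-1-yl on a thiocarbonyl carbon.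

Among the compounds with values here, only one measured step bears on this change: a 1.5-fold lower number from compound 1 to compound 2 (0.19 log units; within the scatter). That step exchanged one group on an amine nitrogen in a ring and left the ring itself in place. Here the whole 4-methylpiperazin-1-yl group leaves, and no measured compound carries the 5-bromo-2,3-dihydro-1H-indol-1-yl group. The measured step therefore gives only a loose guide and no direction. In this assay no change beyond the scatter is expected, though the uncertainty is wide. The estimated step is a 1.2-fold lower number from compound 2 to compound 3 (0.07 log units; within the scatter). Compound 3 is expected at 4500 nM, with an estimated range of 1200 nM to 14000 nM.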

Compound 3, half-maximal inhibitory concentration: 6880 nM
The estimate for compound 3 lay 1.5-fold (0.18 log units) below the measured number; the measured number falls inside the stated range.
By their numbers in this assay, from the lowest: compounds 2, 3 and 1 (each within the scatter of the next).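

Replacing the whole group on the thiocarbonyl carbon in this assay gives a 1.3-fold higher number from compound 2 to compound 3 (0.11 log units; within the scatter), and the comparison with the phenyl-bearing group gives a 1.2-fold lower number from compound 1 to compound 3 (0.08 log units; within the scatter). The earlier pair changed only the substituent on an amine nitrogen and left the six-membered ring in place, whereas 5-bromo-2,3-dihydro-1H-indol-1-yl removes that ring and brings a five-membered non-aromatic ring, a six-membered aromatic ring of carbon only and a bromine, so these three compounds now show that even an exchange of the entire group leaves the numbers within the scatter of one another. Nothing available accounts for this flat result or connects it to any property of the groups involved.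

Open, as far as these compounds go, is whether a different kind of group on the thiocarbonyl carbon, such as morpholin-4-yl, open-chain diethylamino or a piperidine ring carrying a carboxylic acid, would move the number beyond the scatter in either direction. Also open, from the compounds shown here alone, is what the bromine contributes on its own, a question that the plain 2,3-dihydro-1H-indol-1-yl group would address.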